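4-Methylbenzyl to 2-chlorobenzyl on the aromatic nitrogen

The source may hold more compounds than are shown below. What is called first, only, known or untested is meant among the compounds shown, and "the series" means these compounds.

In a functional assay on NCI-H460 cells (Homo sapiens) for cytotoxicity, read by MTT assay, with a stated time of 72 h (a lower number here means a stronger inhibitor, a higher number a weaker inhibitor), compound 2 `CC1CCN(Cc2ccc3nc(NC(=O)N/N=C/c4c[nH]c5ccccc45)sc3c2)CC1`, with hydrogen on the aromatic nitrogen, gives 4130 nM. Compound 1 `CC1CCN(Cc2ccc3nc(NC(=O)N/N=C/c4cn(Cc5cccc(Cl)c5)c5ccccc45)sc3c2)CC1`, carrying 3-chlorobenzyl there, gives 280 nM, and compound 3 `Cc1ccc(Cn2cc(/C=N/NC(=O)Nc3nc4ccc(CN5CCC(C)CC5)cc4s3)c3ccccc32)cc1`, carrying 4-methylbenzyl, gives 410 nM. Compound 3 therefore lies within the scatter of compound 1 and well under compound 2.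

The step under study leads to compound 4 `CC1CCN(Cc2ccc3nc(NC(=O)N/N=C/c4cn(Cc5ccccc5Cl)c5ccccc45)sc3c2)CC1`. The difference is 2-chlorophenyl in place of 4-methylphenyl on a saturated chain carbon bound to an aromatic nitrogen.

For the measured compounds named here, two measured steps concern hydrogen against a benzyl group, and both lie beyond the scatter: a 15-fold higher number from compound 1 to compound 2 (1.17 log units; beyond the scatter) and a 10-fold lower number from compound 2 to compound 3 (1.00 log units; beyond the scatter). They bear only indirectly, since compound 3 and compound 4 both carry a benzyl group. The closer guide is the exchange of one substituted benzyl group for another, a 1.5-fold higher number from compound 1 to compound 3 (0.17 log units; within the scatter), which stays within the scatter. Going by the values given here, no measured compound carries 2-chlorobenzyl, so this single step is thin support.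

In this assay the expected step is a 1.2-fold lower number from compound 3 to compound 4 (0.07 log units; within the scatter), with no firm direction and nothing expected beyond the scatter. Compound 4 is estimated at 350 nM, with an expected range of 150 nM to 850 nM.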

Compound 4, half-maximal inhibitory concentration: 1080 nM
For compound 4 the middle estimate is 3.1-fold (0.49 log units) below the measured one; the measured number lies above the stated range.
By their numbers in this assay, from the lowest: compounds 1 and 3 (each within the scatter of the next); then compound 4; then compound 2.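

In this assay the identity of the substituted benzyl group on the aromatic nitrogen now matters: 3-chlorobenzyl and 4-methylbenzyl stayed within the scatter of each other, but 2-chlorobenzyl departs from both, with a 2.6-fold higher number from compound 3 to compound 4 (0.42 log units; beyond the scatter) and a 3.9-fold higher number from compound 1 to compound 4 (0.59 log units; beyond the scatter) as the two steps. The second of these keeps the chlorine and changes only 3-chlorobenzyl to 2-chlorobenzyl, so a chlorine-bearing benzyl group does not by itself secure the numbers of compound 1, while 2-chlorobenzyl still retains a clear advantage over hydrogen in a 3.8-fold lower number from compound 2 to compound 4 (0.58 log units; beyond the scatter) as the remaining step. No measured evidence accompanies these compounds that would account for the difference between the benzyl groups.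

Still open, going by these compounds, is whether the loss follows the 2-substituted benzyl pattern generally or belongs to chlorine alone, a question that 2-methylbenzyl and 4-chlorobenzyl would help to separate. Unsubstituted benzyl, a longer chain ending in phenyl, and a benzyl group carrying an amine or a carboxylic acid also remain outside the compounds shown.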